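This account rests on a few compounds, and the source may have more. Where it says the series, first, only, none or still open, it means among the compounds named here.

In an ADME assay on MT4 cells (Homo sapiens) for cytotoxicity, read by MTT assay, with a stated time of 4 days (a higher number here means that more compound is tolerated, a lower number that less compound is tolerated), compound 3 `O=C(COc1cccc2ccccc12)N/N=C/c1ccccc1` gives only a limit of the assay, >= 96.6 ug/mL. Compound 3 thus sits at the limit of >= 96.6 ug/mL in this assay, at which 1 of the 3 values shown sits. Compound 1 `Cc1ccc(/C=N/NC(=O)COc2cccc3ccccc23)cc1`, carrying a methyl on an aromatic carbon of that ring, gives 83.9 ug/mL in this assay. Compound 2 `COc1ccc(/C=N/NC(=O)COc2cccc3ccccc23)cc1O`, which carries both a methoxy and a hydroxy on that ring, gives 7.05 ug/mL in this assay. Compound 4 `COc1ccc(/C=N/NC(=O)COc2cccc3ccccc23)cc1` is not yet measured and differs from compound 3 by methoxy in place of hydrogen on an aromatic carbon. Going by the values given here, the one measured step at such a carbon, an at least 1.1-fold higher number from compound 1 to compound 3 (0.06 log units; that floor lies within the scatter), stayed within the scatter, so a methoxy alone is expected to move the number little in this assay, while compound 2 shows that a second group can lower it sharply. Compound 4 is therefore expected to give 60 ug/mL, between 20 ug/mL and 100 ug/mL. That is an expected step of an at least 1.6-fold lower number from compound 3 to compound 4 (0.20 log units; that floor lies within the scatter).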

Compound 4, half-maximal cytotoxic concentration: 76.9 ug/mL
For compound 4 the middle estimate is 1.3-fold (0.11 log units) below the measured one, within the range that was stated.
By their numbers in this assay, from the lowest: compound 2; then compounds 4 and 1 (each within the scatter of the next). At a limit, above all of these: compound 3.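

Methoxy in place of hydrogen on this aromatic carbon keeps the number within the scatter in this assay (an at least 1.2-fold lower number from compound 3 to compound 4 (0.09 log units; that floor lies within the scatter)), and that step is only a floor, since it starts from a limit: the limit of >= 96.6 ug/mL in this assay, at which 1 of the 4 values shown sits. Methoxy and methyl on this carbon also lie within the scatter of each other (a 1.1-fold lower number from compound 1 to compound 4 (0.04 log units; within the scatter)). Hydrogen in place of the hydroxy, by contrast, gives a large step (an 11-fold higher number from compound 2 to compound 4 (1.04 log units; beyond the scatter)), so methoxy alone does not bring the low number seen when the hydroxy is also present.

On these data alone, whether a hydroxy without the methoxy would be enough to lower the number stays open. So does the effect of an amine or a carboxylic acid on this ring.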